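From 3-cyanopropyl to 2-cyanoethyl on the shared core

The source may report more compounds than this note shows. Statements on the series, on what has been measured and on what is new or still open speak of the compounds shown alone.

- Compound 1 `COc1cc(OC)c2cc(-c3ccccc3)c(O)nc2c1` gives 10000 nM
- Compound 2 `COc1ccc(-c2cc3c(OC)cc(OC)cc3n(CCCC#N)c2=O)cc1` gives 10000 nM

In a functional assay on J82 cells (Homo sapiens) for cytotoxicity, read by colorimetric assay and MTT assay (a higher number here means a weaker inhibitor, a lower number a stronger inhibitor), compound 2 gives 10000 nM and stands level with compound 1 at 10000 nM on these numbers, within the scatter of repeated measurements. Neither compound therefore stands apart from the other. Compound 3 `COc1ccc(-c2cc3c(OC)cc(OC)cc3n(CCC#N)c2=O)cc1` has not yet been measured. It differs from compound 2 in one place (cyano in place of cyanomethyl on a saturated chain carbon, two bonds along the chain from an aromatic nitrogen), with cyano in place of cyanomethyl on a saturated chain carbon, two bonds along the chain from an aromatic nitrogen. The same difference, cut one bond further out, reads 3-cyanopropyl to 2-cyanoethyl. Within the data shown here, no measured pair shows this change, so the data offer no direct guide to its size. The nearest reference is compound 2 at 10000 nM and this supports an expectation of no step beyond the scatter, with no direction favoured. The expected change is no change at the digits printed from compound 2 to compound 3 (within the scatter) in this assay on this reasoning. The estimate for compound 3 is 10000 nM with an expected range from 3000 nM to 20000 nM for the coming measurement.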

Compound 3, half-maximal inhibitory concentration: 10000 nM
For compound 3 middle estimate and measured number coincide at the digits printed, within the range that was stated.
By their numbers in this assay, from the lowest: compounds 1, 2 and 3 (each within the scatter of the next).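

In this assay, cyano in place of cyanomethyl on a saturated chain carbon, two bonds along the chain from an aromatic nitrogen, gives no change at the digits printed from compound 2 to compound 3 (within the scatter). Among these compounds, the earlier compounds offered no measured pair for this change, so this is the first direct reading at this position: going from 3-cyanopropyl to 2-cyanoethyl, with the nitrile kept and the counted hydrogen-bond donors and acceptors the same in both groups, leaves the number as it was. Nothing measured on these compounds accounts for this result, so it stands as an observation without an explanation.

What the compounds shown leave open is whether anything placed on this chain can move the value of compound 3 at 10000 nM, for example an amine, a carboxylic acid or a longer chain ending in a nitrile in the same place. They also leave open whether the same change from 3-cyanopropyl to 2-cyanoethyl would read the same way on a compound with a lower number in this assay, since this single step is the only one available.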